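The source may report more compounds than this note shows. Statements on the series, on what has been measured and on what is new or still open speak of the compounds shown alone.

Compound 1, `Cc1ccccc1Oc1ccc(C#N)cc1S(=O)(=O)NC(=O)NC(C)(C)C`, is the starting point of this short series. In a functional assay on HEK293 cells for antagonist activity at thromboxane A2 receptor (Homo sapiens), read by fluorescence and calcium flux (on this read-out lower numbers stand for stronger inhibition and higher numbers for weaker inhibition), compound 1 gives 1470 nM. Compound 2, `CC(C)(C)NC(=O)NS(=O)(=O)c1cc(C#N)ccc1Oc1ccc(F)cc1`, differs from it only in the aryl group on the ether oxygen, and in this assay compound 2 gives 3890 nM. Among the measured compounds shown here, that change is the only measured step so far, a 2.6-fold higher number from compound 1 to compound 2 (0.42 log units; beyond the scatter), so compound 2 stands with the highest number of the two, and compound 1 is its nearest neighbour.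

Compound 3, `CC(C)(C)NC(=O)NS(=O)(=O)c1cc(C#N)ccc1Oc1ccc(Cl)cc1`, is not yet measured. It differs from compound 2 by chloro in place of fluoro on an aromatic carbon, the new atom sitting on an aromatic carbon of a six-membered aromatic ring of carbon only, para to a large group. For the measured compounds named here, no measured step swaps one halogen for another; the one step available, a 2.6-fold higher number from compound 1 to compound 2 (0.42 log units; beyond the scatter), replaced the whole aryl group, so it bears only loosely on this change. On that basis the step of a 1.4-fold lower number from compound 2 to compound 3 (0.14 log units; within the scatter) is expected to stay within the scatter. Compound 3 is therefore estimated at 2800 nM, with a range from 1100 nM to 7000 nM.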

Compound 3, half-maximal inhibitory concentration: 5270 nM
For compound 3 the middle estimate is 1.9-fold (0.27 log units) below the measured one; the measured number falls inside the stated range.
By their numbers in this assay, from the lowest: compound 1; then compounds 2 and 3 (each within the scatter of the next).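

In this assay, among the compounds shown here, the first direct exchange of one halogen for another at this place, para to a large group, gives a 1.4-fold higher number from compound 2 to compound 3 (0.13 log units; within the scatter), so fluoro and chloro cannot be told apart here. Replacing the 2-methylphenyl group of compound 1 with 4-chlorophenyl gives a 3.6-fold higher number from compound 1 to compound 3 (0.55 log units; beyond the scatter), a step beyond the scatter, as was the step to the 4-fluorophenyl group of compound 2, so compound 1 keeps the lowest number of the three. No measured information explains these numbers.

The compounds shown leave open whether the gap to compound 1 follows from the methyl group itself or from where it sits on the ring. They also leave open how a methoxy group or an amine at this place would compare with the two halogens.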